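A few compounds are considered here, and "the series" means these few. Any claim that something is new, unique, unknown or untested is made for them only; others in the source may bear on it.

Compound 1 (`CC(C)Nc1ncnn2ccc(CN3CCC(N)CC3)c12`) and compound 2 (`NC1CCN(Cc2ccn3ncnc(Nc4cccc(Cl)c4)c23)CC1`) share a core, and both were entered for testing in a functional assay on A2780 cells (Homo sapiens) for antiproliferative activity; on this read-out higher numbers stand for weaker inhibition and lower numbers for stronger inhibition. For compound 1 the record reads "not determined" (no result reported), so it offers no number to compare. Compound 2 is recorded in this assay only as a limit, > 5000 nM, and not as a measured number. Compound 3 (`NC1CCN(Cc2ccn3ncnc(Nc4cccc(Br)c4)c23)CC1`) has bromo in place of chloro on an aromatic carbon of compound 2, the 3-chlorophenyl becoming 3-bromophenyl (bromo in place of chloro on an aromatic carbon). Going by the values given here, no step between measured compounds is available as a guide, so the expectation rests on the limit of compound 2 alone. The expected change a step that the limit leaves unreadable from compound 2 to compound 3 in this assay is none beyond the usual scatter, with a reading again likely to be only a limit. For compound 3 the expected value is 7000 nM, with an estimated range of 2500 nM to 20000 nM.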

Compound 3, half-maximal inhibitory concentration: 2600 nM
The estimate for compound 3 lay 2.7-fold (0.43 log units) above the measured number; the measured number falls inside the stated range.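

Going by these compounds alone, compound 3 is the only one of the three compounds that carries a single number in this assay, which gives this position on the aromatic ring a measured reading for the first time. Compound 2 stands there only as a limit, > 5000 nM. Bromo in place of chloro on an aromatic carbon gives an at least 1.9-fold lower number from compound 2 to compound 3 (0.28 log units; that floor lies within the scatter), so the true size of the step stays unknown and it cannot be called a change beyond the scatter, because one end of it is a limit: the limit of > 5000 nM in this assay, at which 1 of the 3 values shown sits.

From the compounds shown here alone, it remains open how a methoxy or a trifluoromethyl at the same place would read in this assay, or a plain phenyl carrying no halogen at all. With only one single number at hand, the compounds shown also leave open whether this position has any trend across groups.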